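The source may hold more compounds than are shown below. What is called first, only, known or untested is meant among the compounds shown, and "the series" means these compounds.

Compound 2 `O=C(CN1CCN(c2cc3c(cc2F)c(=O)c(C(=O)O)cn3C2CC2)CC1)Nc1ccc(Cl)cc1` is one of two measured compounds that share their core with compound 3. In an ADME assay on WI-38 cells (Homo sapiens) for antiproliferative activity, read by BrdU incorporation, with a stated time of 24 h (a lower number here means a stronger inhibitor, a higher number a weaker inhibitor), compound 2 gives > 100000 nM, which is a limit of the assay rather than a number. Its neighbour, compound 1 `O=C(CN1CCN(c2cc3c(cc2F)c(=O)c(C(=O)O)cn3C2CC2)CC1)Nc1ccccc1`, differs from compound 2 in one place: chloro in place of hydrogen on an aromatic carbon. In this assay compound 1 gives > 100000 nM, again a limit and not a number. The step that the two limits leave unreadable from compound 1 to compound 2 therefore cannot be read, because of the limit of > 100000 nM in this assay, at which 2 of the 2 values shown sit.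

Compound 3 `COc1ccccc1NC(=O)CN1CCN(c2cc3c(cc2F)c(=O)c(C(=O)O)cn3C2CC2)CC1` has not been measured. It differs from compound 2 in one place: 2-methoxyphenyl in place of 4-chlorophenyl on an amide-type nitrogen. For the measured compounds named here, only the step from compound 1 to compound 2 bears on this change, and it has no readable size, so it gives neither a direction nor a magnitude to build on. The expectation is that compound 3 stays at the same limit, so the estimated step that the limit leaves unreadable from compound 2 to compound 3 is none beyond the scatter. For compound 3 the estimate in this assay is 150000 nM, within a range from 30000 nM to 1000000 nM.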

Compound 3, half-maximal inhibitory concentration: > 100000 nM
Compound 3: no number, only a limit; the forecaster's own chance of this, stated with the estimate: 85%; the middle value lies beyond the limit too.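

In this assay compound 3 gives > 100000 nM, which is a limit of the assay and not a number. No new step from compound 1 or compound 2 to compound 3 can be read, because all three compounds share one limit: the limit of > 100000 nM in this assay, at which 3 of the 3 values shown sit.

The compounds shown leave open how the group on the amide-type nitrogen affects activity, since none yields a readable value.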